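A few compounds are considered here, and "the series" means these few. Any claim that something is new, unique, unknown or untested is made for them only; others in the source may bear on it.

Of the compounds shown here, three have so far been measured in an ADME assay on L02 cells (Homo sapiens) for cytotoxicity, read by MTT assay, with a stated time of 24 h; on this read-out higher numbers stand for weaker inhibition and lower numbers for stronger inhibition. Compound 1 `CN1C/C(=C\c2cccnc2)C(=O)/C(=C/c2ccccc2F)C1` gives 15900 nM in this assay. Compound 2 `CN1C/C(=C\c2cccnc2)C(=O)/C(=C/c2ccccc2C(F)(F)F)C1` gives 14100 nM in this assay. These two differ in one place: fluoro in place of trifluoromethyl on an aromatic carbon. That change made a 1.1-fold higher number from compound 2 to compound 1 (0.05 log units; within the scatter), so the two numbers sit within the usual scatter of each other.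

Compound 3 `O=C1/C(=C/c2cccnc2)CN(S(=O)(=O)c2ccc(C(F)(F)F)cc2)C/C1=C\c1ccccc1F` gives 11300 nM in this assay. The difference between the core of compound 3 and the core of compound 2 is not broken down here. All three numbers lie within the scatter of one another, so none of the three can be called stronger or weaker than the others.

Compound 4 `O=C1/C(=C/c2cccnc2)CN(S(=O)(=O)c2ccc(F)cc2)C/C1=C\c1ccccc1F` has not yet been measured. It differs from compound 3 in one place: fluoro in place of trifluoromethyl on an aromatic carbon. Among the measured compounds shown here, this is the same kind of change as the one from compound 2 to compound 1, but not the same: in compound 1 the fluoro sits ortho to a large group, whereas in compound 4 it sits para to a large group.

Compound 4 is expected to give about 12500 nM in this assay, with a likely range from 7000 nM to 22000 nM, because a 1.1-fold higher number from compound 2 to compound 1 (0.05 log units; within the scatter) stayed within the scatter and the same kind of change is made here. For compound 4 the expected step is therefore a 1.1-fold higher number from compound 3 to compound 4 (0.04 log units; within the scatter), again within the scatter.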

Compound 4, half-maximal inhibitory concentration: 15600 nM
Estimate against measurement, compound 4: 1.2-fold (0.10 log units) below, and the stated range covers the measured number.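

In this assay, putting fluoro in place of trifluoromethyl on the second core gave a 1.4-fold higher number from compound 3 to compound 4 (0.14 log units; within the scatter). Set beside the earlier step, the change reads the same on both cores: the same change on two cores in this assay, a 1.1-fold higher number (0.05 log units; within the scatter) from compound 2 to compound 1 and a 1.4-fold higher number (0.14 log units; within the scatter) from compound 3 to compound 4, 1.2-fold (0.09 log units) apart, within the scatter of two such steps This shows only that the swap stayed within the scatter on the two cores shown; with steps this small, it does not show that the swap has no effect at all, nor that a real but small effect is shared by the two cores, and two cores are too few to predict what it would do on a third.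

The step on the ring nitrogen, with (4-fluorophenyl)sulfonyl in place of methyl, gave a 1.0-fold lower number from compound 1 to compound 4 (0.01 log units; within the scatter), also within the scatter, so the compounds shown leave open whether any change at that nitrogen or on the aromatic ring can move this number beyond the scatter. A carboxylic acid, an amine or a longer chain in place of the fluoro is not among these compounds, and what such a group would do to the number remains open.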